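The source may report more compounds than this note shows. Statements on the series, on what has been measured and on what is new or still open speak of the compounds shown alone.

Values in an ADME assay on L929 cells (Mus musculus) for cytotoxicity, read by resazurin assay, with a stated time of 48 h; on this read-out lower numbers stand for higher toxicity in this test and higher numbers for lower toxicity in this test:
compound 1 `C=Cn1c2ccc([N+](=O)[O-])cc2c(=O)n1Cc1ccccc1`: 160000 nM
compound 2 `NC(=O)CCCn1c2ccc([N+](=O)[O-])cc2c(=O)n1Cc1ccccc1`: > 256000 nM, a limit
compound 3 `O=c1c2cc([N+](=O)[O-])ccc2n(CCCO)n1Cc1ccccc1`: > 256000 nM, a limit

Compound 3 stands at > 256000 nM, which is a limit of the assay and not a number. Compound 4 `O=C(OCc1ccccc1)n1c2ccc([N+](=O)[O-])cc2c(=O)n1Cc1ccccc1` carries benzyloxycarbonyl in place of 3-hydroxypropyl on an aromatic nitrogen. Two measured steps change this same nitrogen substituent: an at least 1.6-fold higher number from compound 1 to compound 3 (0.20 log units; that floor lies within the scatter) and an at least 1.6-fold higher number from compound 1 to compound 2 (0.20 log units; that floor lies within the scatter). Among the compounds with values here, neither step reaches beyond the scatter, and the only true number is that of compound 1, at 160000 nM. A modest move toward lower numbers in this assay is therefore expected, possibly none beyond the scatter. The expected step is an at least 1.9-fold lower number from compound 3 to compound 4 (0.29 log units; that floor lies within the scatter). For compound 4 the estimate is 130000 nM, with an expected range of 45000 nM to 256000 nM.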

Compound 4, concentration lethal to 50% of the cells: 86100 nM
Estimate against measurement, compound 4: 1.5-fold (0.18 log units) above; low and high end bracket the measured number.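

In this assay, benzyloxycarbonyl in place of 3-hydroxypropyl or 3-carbamoylpropyl on this aromatic nitrogen gives steps beyond the scatter: an at least 2.9-fold lower number from compound 3 to compound 4 (0.47 log units; beyond the scatter) and an at least 2.9-fold lower number from compound 2 to compound 4 (0.47 log units; beyond the scatter). Against the vinyl of compound 1 the same group stays within the scatter: a 1.9-fold lower number from compound 1 to compound 4 (0.27 log units; within the scatter). Both larger steps start from a limit of the assay and not from a number: the limit of > 256000 nM in this assay, at which 2 of the 4 values shown sit.

As far as these compounds go, whether the benzyl part or the carbonyl of benzyloxycarbonyl goes with these steps stays open. So does what an acetyl group, an aminopropyl chain or a carboxylic acid chain would give on this nitrogen.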